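Lengthening the acid chain of compound 1

The compounds below may be only part of what the source reports. "The series", "measured", "known", "first", "only" and "open" are said of these compounds alone.

Measured in a physicochemical assay for lipophilicity, at pH 7.4; a higher number here means a more lipophilic compound, a lower number a more polar compound:
- compound 1 `CC(C)Oc1ccc(-c2nnc(-n3cc4c(n3)CCN(CCC(=O)O)C4)s2)cc1Cl`: 3.26
- compound 2 `CC(C)Oc1ccc(-c2nnc(-c3ccno3)s2)cc1Cl`: 6.93

Of these two compounds, compound 1 holds the lower number, and the gap up to compound 2 lies well beyond the scatter. Compound 3 `CC(C)Oc1ccc(-c2nnc(-n3cc4c(n3)CCN(CCCC(=O)O)C4)s2)cc1Cl` is still unmeasured. It departs from compound 1 by one change, carboxymethyl in place of carboxy on a saturated chain carbon, two bonds along the chain from an amine nitrogen in a ring. Cut one bond further out, this reads 2-carboxyethyl to 3-carboxypropyl. Going by the values given here, no measured pair differing in one place is available to calibrate this change, so the expectation is tentative. In this assay a small rise is expected, a number 0.14 log units higher from compound 1 to compound 3 (within the scatter), not clearly beyond the scatter. The estimated value for compound 3 is 3.4, with an expected range of 3 to 3.8.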

Compound 3, distribution coefficient: 3.56
Compound 3: the middle estimate sits 0.16 log units below what was measured; the measured number falls inside the stated range.
By their numbers in this assay, from the lowest: compounds 1 and 3 (each within the scatter of the next); then compound 2.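

In this assay, carboxymethyl in place of carboxy on a saturated chain carbon, two bonds along the chain from an amine nitrogen in a ring, gives a number 0.30 log units higher from compound 1 to compound 3 (within the scatter). Going by these compounds alone, this is the first one-place calibration of the change: at this position, the acid chain can read 3-carboxypropyl rather than 2-carboxyethyl without a separation from compound 1 beyond the usual scatter. No supporting data explain the size of this step.

From the compounds shown here alone, whether a longer chain than 3-carboxypropyl would also stay within the scatter of compound 1 remains open, as does the outcome of an amide or a primary amine in place of the carboxylic acid at the chain end. A single step also leaves open whether the same change would read alike on a different core.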